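Swapping a fluorinated alcohol for fluoromethyl in compound 2

The compounds below may be only part of what the source reports. "The series", "measured", "known", "first", "only" and "open" are said of these compounds alone.

Compound 1 `N#CC1(c2cc(CC(O)C3CC3)cc(-c3ccnc4[nH]nc(C(F)(F)F)c34)c2)CC1` gives 0%
Compound 2 `N#CC1(c2cc(CC(O)C(F)(F)F)cc(-c3ccnc4[nH]nc(C(F)(F)F)c34)c2)CC1` gives 71%
Compound 3 `COCCc1cc(-c2ccnc3[nH]nc(C(F)(F)F)c23)cc(C2(C#N)CC2)c1` gives 90%

These three values come from an ADME assay on S9 fraction from liver (Rattus norvegicus) for metabolic stability, read by LC-MS, using NADPH, with a stated time of 60 min, tested at 10 uM (on this read-out lower numbers stand for a less stable compound and higher numbers for a more stable compound), and they place compound 2 second of the three, below compound 3 and above compound 1, with both gaps beyond the scatter. Compound 4 `N#CC1(c2cc(CCF)cc(-c3ccnc4[nH]nc(C(F)(F)F)c34)c2)CC1` has not yet been measured. It differs from compound 2 by a single change (fluoromethyl in place of 2,2,2-trifluoro-1-hydroxyethyl on a saturated chain carbon bound to an aromatic carbon), with fluoromethyl in place of 2,2,2-trifluoro-1-hydroxyethyl on a saturated chain carbon bound to an aromatic carbon.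

For the measured compounds named here, no measured compound carries fluoromethyl, so the evidence is indirect. All three measured steps change the group at this same place. Two of them are large, a number 71 percentage points higher from compound 1 to compound 2 (beyond the scatter) and a number 90 percentage points higher from compound 1 to compound 3 (beyond the scatter), and both start from compound 1, whose cyclopropyl(hydroxy)methyl group is not involved in the new change. The closest guide is a number 19 percentage points higher from compound 2 to compound 3 (beyond the scatter), a modest step that also starts from compound 2 and removes the same group, putting methoxymethyl in its place. A modest rise is therefore expected, and the estimated move is a number 11 percentage points higher from compound 2 to compound 4 (beyond the scatter) in this assay terms.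

For compound 4 the estimated value is 82%, with an expected range from 60% to 98% in this measurement.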

Compound 4, percent of the compound remaining: 67%
The estimate for compound 4 lay 15 percentage points above the measured number, and the stated range covers the measured number.
By their numbers in this assay, from the lowest: compound 1; then compounds 4 and 2 (each within the scatter of the next); then compound 3.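

In this assay, the change to 2-fluoroethyl gives a number 4 percentage points lower from compound 2 to compound 4 (within the scatter), so this position accepts a much smaller group with no hydrogen-bond donor and no trifluoromethyl without a readable change from the 3,3,3-trifluoro-2-hydroxypropyl of compound 2. For the compounds shown here, the step of a number 67 percentage points higher from compound 1 to compound 4 (beyond the scatter) shows that a simple fluorinated chain also stands far from the cyclopropyl(hydroxy)methyl group of compound 1, which therefore remains the only low compound of the four. The chain end still matters, since fluoro in place of methoxy reads as a number 23 percentage points lower from compound 3 to compound 4 (beyond the scatter) and leaves methoxymethyl apart from fluoromethyl at this place.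

The data give no explanation for any of these steps. The compounds shown leave open how a plain 2-hydroxyethyl chain, a cyclopropylmethyl chain without the hydroxyl, an amine, a carboxylic acid or a longer ether chain would read at this position, and so they do not separate the separate contributions of the hydroxyl, the cyclopropyl and the trifluoromethyl.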